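Diaryl ether pyrrolidine acids: notes on the series

This account rests on a few compounds, and the source may have more. Where it says the series, first, only, none or still open, it means among the compounds named here.

Measured so far:
compound 1 `Cc1ccccc1Cc1ccc(N2CCC[C@@]2(C)CC(=O)O)cc1` – 23000 nM
compound 2 `O=C(O)C[C@@H]1C[C@H](C(F)(F)F)CN1c1ccc(Oc2ccccc2C(F)(F)F)cc1` – "not determined" (no result reported)
compound 3 `O=C(O)C[C@@H]1C[C@H](C(F)(F)F)CN1c1ccc(Oc2ccccc2OC(F)(F)F)cc1` – "not determined" (no result reported)

In an assay on HEK293 cells for binding affinity to Free fatty acid receptor 1 (Homo sapiens), read by scintillation counting and radioligand binding, with a stated time of 1 h (a lower number here means a stronger inhibitor, a higher number a weaker inhibitor), compound 1 gives 23000 nM, a weak result. For compound 2 no number is available in this assay, only the entry "not determined" (no result reported). Compound 3 likewise stands without a number in this assay. Going by the values given here, no pair of measured compounds differs in a single place, so no step is established, and compound 2 has no numerical standing among the three.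

Compound 4 `COc1ccc(Oc2ccc(N3C[C@@H](C(F)(F)F)C[C@H]3CC(=O)O)cc2)c(C)c1` differs from compound 2 by 4-methoxy-2-methylphenyl in place of 2-(trifluoromethyl)phenyl on an oxygen on an aromatic ring. With no number for compound 2 in this assay, neither the size nor the direction of this step can be read from the data; only the weak value of compound 1, on a different core, is known. Compound 4 is expected to give roughly 300 nM in this assay, with an estimated range from 30 nM to 3000 nM.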

Compound 4, inhibition constant: 39 nM
The estimate for compound 4 lay 7.7-fold (0.89 log units) above the measured number; low and high end bracket the measured number.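

Compound 4 gives 39 nM in this assay but compound 2 has no number there, so no step can be read between compound 2 and compound 4. As far as these compounds go, what 4-methoxy-2-methylphenyl in place of 2-(trifluoromethyl)phenyl contributes on its own stays open. No evidence bears on this result.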